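This account rests on a few compounds, and the source may have more. Where it says the series, first, only, none or still open, it means among the compounds named here.

Compound 2 `CCCCCNc1nc(N)c2nc(O)n(Cc3ccccc3)c2n1` stands second highest of the three numbers in a functional assay on the whole organism for activation, with Mus musculus as the target; a higher number here means that more compound is needed for the effect, a lower number that less compound is needed: compound 2 gives 0.3 mg/kg. Compound 3 `CCCCOc1nc(N)c2[nH]c(=O)n(Cc3ccccc3)c2n1` gives 0.1 mg/kg in this assay, a lower number beyond the scatter. Compound 1 `Nc1ncnc2c1nc(O)n2Cc1ccc(Cl)cc1`, unsubstituted at the carbon in question and bearing a chloro group on the benzyl ring, gives 30 mg/kg, a higher number, also beyond the scatter. For the measured compounds named here, no step between two measured compounds differing in a single place is available. Compound 4 `CCc1nc(N)c2nc(O)n(Cc3ccccc3)c2n1` differs from compound 2 in one way: ethyl in place of pentylamino on an aromatic carbon. In this assay a step to a higher number beyond the scatter is expected, because compound 1 with nothing at that carbon gives 30 mg/kg. Compound 4 is expected at 3 mg/kg, between 0.5 mg/kg and 20 mg/kg. The expected step is a 10-fold higher number from compound 2 to compound 4 (1.00 log units; beyond the scatter).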

Compound 4, minimum effective dose: 3 mg/kg
Estimate against measurement, compound 4: no gap at the digits printed; the measured number falls inside the stated range.
By their numbers in this assay, from the lowest: compound 3; then compound 2; then compound 4; then compound 1.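

In this assay, for the compounds shown here, ethyl in place of pentylamino on the aromatic carbon between two ring nitrogen atoms gives a 10-fold higher number from compound 2 to compound 4 (1.00 log units; beyond the scatter), the first single-place change that can be read at this position. The step shows that the number responds to the group held here, but the nitrogen link and the chain length change together, so their shares cannot be separated. No measurement on hand accounts for the step. From the compounds shown here alone, whether ethylamino or a directly attached pentyl would match pentylamino remains open, as does the effect of a longer chain such as heptylamino.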